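From methoxy to ethoxy at the assay limit

The compounds below may be only part of what the source reports. "The series", "measured", "known", "first", "only" and "open" are said of these compounds alone.

In a functional assay on DU-145 cells (Homo sapiens) for cytotoxicity, read by MTT assay, with a stated time of 72 h (a lower number here means a stronger inhibitor, a higher number a weaker inhibitor), compound 1 `CCN(CC)c1cc2nc(-c3ccccc3)nn(-c3ccccc3)c-2cc1=O` gives 3110 nM and compound 2 `O=c1cc2n(-c3ccccc3)nc(-c3ccccc3)nc-2cc1N1CCCCC1` gives 610 nM. Compound 3 `COc1cc2nc(-c3ccccc3)nn(-c3ccccc3)c-2cc1=O` reads > 5000 nM, which is a limit of the assay and not a number. Compound 4 `CCOc1cc2nc(-c3ccccc3)nn(-c3ccccc3)c-2cc1=O` differs from it by methyl in place of hydrogen on a saturated chain carbon bound to an oxygen on an aromatic ring: methyl in place of hydrogen, turning methoxy into ethoxy. The closest evidence comes from swapping the whole group on the aromatic carbon. Those swaps gave a 5.1-fold lower number from compound 1 to compound 2 (0.71 log units; beyond the scatter), then an at least 8.1-fold higher number from compound 2 to compound 3 (0.91 log units; beyond the scatter), while an at least 1.6-fold higher number from compound 1 to compound 3 (0.20 log units; that floor lies within the scatter). Extending methoxy to ethoxy is a much smaller change, so only a small shift is expected in this assay, none beyond the scatter. The expected step is a step that the limit leaves unreadable from compound 3 to compound 4. Compound 4 is estimated at 6000 nM, with an expected range of 2500 nM to 15000 nM.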

Compound 4, half-maximal inhibitory concentration: > 5000 nM
Compound 4 was reported as a limit; the forecaster's own chance of this, stated with the estimate: 60%; the middle value lies beyond the limit too.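

In this assay compound 4 reads > 5000 nM as a limit of the assay and not a number. The step from methoxy to ethoxy cannot be read, because compound 3 and compound 4 both stand at that limit: the limit of > 5000 nM in this assay, at which 2 of the 4 values shown sit. Ethoxy on the aromatic carbon gives an at least 8.1-fold higher number from compound 2 to compound 4 (0.91 log units; beyond the scatter) and an at least 1.6-fold higher number from compound 1 to compound 4 (0.20 log units; that floor lies within the scatter) when set against the two amino groups.

As far as these compounds go, how far above the limit either ether lies stays open. A longer chain such as butoxy, or a smaller amine such as dimethylamino, would test this position further.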